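This account rests on a few compounds, and the source may have more. Where it says the series, first, only, none or still open, it means among the compounds named here.

Working notes on the series. Compound 1 `CCOC(=O)CC[C@H](NC(=O)c1ccc(CNc2ccc3nc(N)nc(N)c3c2)cc1)C(=O)OCC` is the reference: in an assay for inhibition of Dihydrofolate reductase (Homo sapiens) (on this read-out higher numbers stand for higher potency (the scale is a negative logarithm) and lower numbers for lower potency), compound 1 gives 7.54. Compound 3 `Nc1nc(N)c2c(Sc3ccc4ccccc4c3)cccc2n1` gives 6.92 in this assay, and compound 2 `Nc1nc(O)c2c(Sc3ccc4ccccc4c3)cccc2n1` gives 6.15. How the core of compound 1 differs from the core of compound 3 is not broken down here. The change from compound 3 to compound 2 is hydroxy in place of amino on an aromatic carbon, and this assay records a number 0.77 log units lower from compound 3 to compound 2 (beyond the scatter) for it. Compound 4 `CCOC(=O)CC[C@H](NC(=O)c1ccc(CNc2ccc3nc(N)nc(O)c3c2)cc1)C(=O)OCC` is not yet measured; it carries the same change relative to compound 1, (hydroxy in place of amino on an aromatic carbon), at a place described in the same words. For compound 4 a step of a number 0.74 log units lower from compound 1 to compound 4 (beyond the scatter) is expected, set beside the earlier one because the same change gave a number 0.77 log units lower from compound 3 to compound 2 (beyond the scatter). Compound 4 is therefore estimated at 6.8, between 6.2 and 7.3.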

Compound 4, logarithm of the reciprocal of the active concentration, log(1/C): 6.24
Beside the measured number, compound 4's estimate is 0.56 log units above it; low and high end bracket the measured number.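

Hydroxy in place of amino on an aromatic carbon lowers the number on both cores in this assay, and the new step reads a number 1.30 log units lower from compound 1 to compound 4 (beyond the scatter). The direction carries over from one core to the other, but the size does not: the same change on two cores in this assay, a number 0.77 log units lower (beyond the scatter) from compound 3 to compound 2 and a number 1.30 log units lower (beyond the scatter) from compound 1 to compound 4, 0.53 log units apart, beyond the scatter of two such steps

Two cores give no rule for the size of this step on a further core, and they do not show which part of the cores sets the gap. The compounds shown leave open how the two cores respond to other groups at this place, such as methoxy or a methylamine. They also leave open whether a free carboxylic acid in place of the ethyl esters of compound 1 and compound 4 would alter the step.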